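Amide Extension of the Aniline: What Compound 4 Should Tolerate

A few compounds are considered here, and "the series" means these few. Any claim that something is new, unique, unknown or untested is made for them only; others in the source may bear on it.

Compound 3 `Cn1c(-c2ccc(N)cc2)nc2cc(C(F)(F)F)ccc21` gives 85000 nM in an ADME assay on BHK cells (Mesocricetus auratus) for cytotoxicity, read by MTT assay, with a stated time of 96 h (a higher number here means that more compound is tolerated, a lower number that less compound is tolerated), the highest of the two numbers in hand. Compound 2 `CN1CCN(CC(=O)Nc2ccc(-c3nc4cc(C(F)(F)F)ccc4n3C)cc2)CC1` gives 16000 nM in this assay. Compound 1 `Cn1c(-c2ccc([N+](=O)[O-])cc2)nc2cc(C(F)(F)F)ccc21` reaches only the limit of this assay at > 100000 nM (the limit of > 100000 nM in this assay, at which 1 of the 3 values shown sits). The step of an at least 1.1-fold lower number from compound 1 to compound 3 (0.07 log units; that floor lies within the scatter) lies within the scatter. Compound 4 `Cn1c(-c2ccc(NC(=O)CN3CCCCC3)cc2)nc2cc(C(F)(F)F)ccc21` differs from compound 3 by ((piperidin-1-yl)methyl)carbonyl in place of hydrogen on a nitrogen on an aromatic ring. Among the compounds with values here, the one step that bears on this is a 5.3-fold higher number from compound 2 to compound 3 (0.73 log units; beyond the scatter), which removed a closely related group in the opposite direction; putting such a group back is expected to lower the number by a comparable, modest amount. Compound 4 is therefore estimated at 20000 nM, expected between 8000 nM and 50000 nM, a step of a 4.3-fold lower number from compound 3 to compound 4 (0.63 log units; beyond the scatter).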

Compound 4, half-maximal cytotoxic concentration: > 100000 nM
Compound 4: a limit, no number; the forecaster's own chance of this, stated with the estimate: 5%; at least 5.0-fold (0.69 log units) between middle value and limit.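

In this assay compound 4 gives a limit and not a number, the same limit as compound 1: the limit of > 100000 nM in this assay, at which 2 of the 4 values shown sit. Extending the amino group to (((piperidin-1-yl)methyl)carbonyl)amino therefore brought no measurable lowering, with an at least 1.1-fold higher number from compound 3 to compound 4 (0.07 log units; that floor lies within the scatter). The lower number of compound 2 thus goes with its 4-methylpiperazin-1-yl group and not with the amide as such, as piperidin-1-yl in its place gives an at least 6.2-fold higher number from compound 2 to compound 4 (0.79 log units; beyond the scatter).

The step from compound 1 to compound 4 cannot be read, as both values are limits. On these data alone, whether a morpholine ring in place of piperidin-1-yl would stay at the limit or fall toward compound 2 remains open.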